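Acetyl in place of methyl on the ring amine nitrogen

The compounds below may be only part of what the source reports. "The series", "measured", "known", "first", "only" and "open" are said of these compounds alone.

Compound 1 `Cc1c2c(n3c1CCCN[C@@H](C)[C@H](C)Nc1cc-3ccc1C(N)=O)CC(C)(C)CC2=O`: 20 nM
Compound 2 `Cc1c2c(n3c1CCCN(C)[C@@H](C)[C@H](C)Nc1cc-3ccc1C(N)=O)CC(C)(C)CC2=O`: 69 nM
Compound 3 `Cc1c2c(n3c1CCN(C)C[C@@H](C)[C@H](C)Nc1cc-3ccc1C(N)=O)CC(C)(C)CC2=O`: 27 nM

In a functional assay on NCI-H1975 cells (Homo sapiens) for antiproliferative activity (a higher number here means a weaker inhibitor, a lower number a stronger inhibitor), compound 2 gives 69 nM, the highest number of the three and beyond the scatter from both compound 1 and compound 3. The next compound is compound 4 `CC(=O)N1CCCc2c(C)c3c(n2-c2ccc(C(N)=O)c(c2)N[C@@H](C)[C@@H]1C)CC(C)(C)CC3=O`, with acetyl in place of methyl on an amine nitrogen in a ring. Within the data shown here, one measured step bears on this nitrogen: a 3.5-fold higher number from compound 1 to compound 2 (0.54 log units; beyond the scatter), for methyl in place of hydrogen. Among the measured compounds shown here, no measured compound carries acetyl there, so the size of the next step is poorly constrained. A further modest rise in this assay is expected by analogy with that step. The expected step is a 1.6-fold higher number from compound 2 to compound 4 (0.20 log units; within the scatter). For compound 4 the estimate is 110 nM, with an expected range of 35 nM to 400 nM.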

Compound 4, half-maximal inhibitory concentration: 20 nM
The estimate for compound 4 lay 5.5-fold (0.74 log units) above the measured number; measured number below the stated range.
By their numbers in this assay, from the lowest: compounds 1, 4 and 3 (each within the scatter of the next); then compound 2.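

In this assay, acetyl in place of methyl gives a 3.5-fold lower number from compound 2 to compound 4 (0.54 log units; beyond the scatter), while acetyl in place of hydrogen gives no change at the digits printed from compound 1 to compound 4 (within the scatter). Substitution on this ring nitrogen therefore does not raise the number as such: among hydrogen, methyl and acetyl, only methyl in compound 2 stands apart. Nothing available here accounts for the difference between methyl and acetyl.

The compounds shown leave open whether a longer acyl chain, a sulfonyl group or a urea on this nitrogen would match acetyl. Also open, from the compounds shown here alone, is how acetyl would behave with the nitrogen placed as in compound 3.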